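Hydroxy to amino at the chain end of compound 3

This account rests on a few compounds, and the source may have more. Where it says the series, first, only, none or still open, it means among the compounds named here.

Measured so far:
- compound 1, `CC(C)(C)OC(=O)NCCCNC(=O)CN1CN(c2ccccc2)C2(CCN(C(=O)c3ccc(C4CCCCC4)cc3)CC2)C1=O`, 6000 nM
- compound 2, `CC1CCCN(C(=O)CN2CN(c3ccccc3)C3(CCN(C(=O)c4ccc(C5CCCCC5)cc4)CC3)C2=O)C1`, 3600 nM
- compound 3, `O=C(CN1CN(c2ccccc2)C2(CCN(C(=O)c3ccc(C4CCCCC4)cc3)CC2)C1=O)NCCO`, 2000 nM

In an assay on HEK293 cells for displacement of a labelled ligand from NPC1-like intracellular cholesterol transporter 1 (Homo sapiens) (on this read-out lower numbers stand for stronger inhibition and higher numbers for weaker inhibition), compound 3 stands with the lowest number of the three, though compound 2 lies within the scatter of it; only compound 1 is separated from it, by a 3.0-fold lower number from compound 1 to compound 3 (0.48 log units; beyond the scatter). Compound 4, `NCCNC(=O)CN1CN(c2ccccc2)C2(CCN(C(=O)c3ccc(C4CCCCC4)cc3)CC2)C1=O`, differs from compound 3 in one place: amino in place of hydroxy on a saturated chain carbon, two bonds along the chain from an amide-type nitrogen. Going by the values given here, no measured step exchanges hydroxy for amino directly. The nearest steps are a 3.0-fold lower number from compound 1 to compound 3 (0.48 log units; beyond the scatter), which arrived at the hydroxy from a larger group, and a 1.8-fold lower number from compound 2 to compound 3 (0.26 log units; within the scatter), a step within the scatter; both concern the same chain end. Since the change is small and the neighbouring steps were modest, compound 4 is expected to show no change at the digits printed from compound 3 to compound 4 (within the scatter) in this assay, no change beyond the scatter. The estimate for compound 4 is 2000 nM, in the range 800 nM to 5000 nM.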

Compound 4, half-maximal inhibitory concentration: 3800 nM
The estimate for compound 4 lay 1.9-fold (0.28 log units) below the measured number, within the range that was stated.
By their numbers in this assay, from the lowest: compounds 3, 2, 4 and 1 (each within the scatter of the next, the first and the last beyond it).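

In this assay the free amino group is accepted at this chain end in place of hydroxy, giving a 1.9-fold higher number from compound 3 to compound 4 (0.28 log units; within the scatter) and no change that can be told from the scatter. Unlike compound 3, which stood apart from compound 1 beyond the scatter, compound 4 is level with both other compounds, showing a 1.1-fold higher number from compound 2 to compound 4 (0.02 log units; within the scatter) and a 1.6-fold lower number from compound 1 to compound 4 (0.20 log units; within the scatter) as its steps. No evidence is available to explain this result. On these data alone, whether a carboxylic acid at this chain end, or a longer chain carrying the amine, would move the number beyond the scatter remains open.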